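Moving a methoxy group around the phenoxy ring

The compounds below may be only part of what the source reports. "The series", "measured", "known", "first", "only" and "open" are said of these compounds alone.

Measured compounds:
- compound 1, `Fc1ccc(Oc2ccc3c(NCCCNCc4ccco4)ccnc3c2)cc1`: 14500 nM
- compound 2, `COc1cccc(Oc2ccc3c(NCCCNCc4cccc(OC)c4O)ccnc3c2)c1`: 14500 nM
- compound 3, `COc1ccc(Oc2ccc3c(NCCCNCc4ccco4)ccnc3c2)cc1`: 14500 nM

In a physicochemical assay for solubility, with a stated time of 18 h, at pH 7.4 (a lower number here means a less soluble compound, a higher number a more soluble compound), compound 3 gives 14500 nM, level with compound 1 and compound 2 at the digits shown. For the measured compounds named here, the only step between measured compounds that differ in one place, no change at the digits printed from compound 1 to compound 3 (within the scatter), left the value unchanged within the scatter. Compound 4, `COc1cccc(Oc2ccc3c(NCCCNCc4ccco4)ccnc3c2)c1`, has not yet been measured in this assay. It differs from compound 3 as follows: 3-methoxyphenyl in place of 4-methoxyphenyl on an oxygen on an aromatic ring. Going by the values given here, no measured pair isolates this exact change, but compound 2 already carries a 3-methoxyphenoxy group on the shared core with a different amine tail, and in this assay compound 2 gives 14500 nM, the same figure as compound 3. Taken with the flat step from compound 1 to compound 3, the expectation is a step of no change at the digits printed from compound 3 to compound 4 (within the scatter), that is, none beyond the scatter. Compound 4 is therefore estimated at 14500 nM, with a range from 7000 nM to 22000 nM.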

Compound 4, solubility: 14500 nM
Compound 4: middle estimate and measured number agree at the digits printed; low and high end bracket the measured number.
By their numbers in this assay, from the lowest: compounds 1, 2, 3 and 4 (each within the scatter of the next).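

In this assay, for the compounds shown here, 3-methoxyphenyl in place of 4-methoxyphenyl on the oxygen gives no change at the digits printed from compound 3 to compound 4 (within the scatter) with the rest of the molecule held the same, the first direct reading of where the methoxy sits on this ring. Replacing 4-fluorophenyl with 3-methoxyphenyl on that same oxygen gives no change at the digits printed from compound 1 to compound 4 (within the scatter) as well, so a second swap at this place also leaves the value unmoved. At a different place, furan-2-yl in place of 2-hydroxy-3-methoxyphenyl on the saturated chain carbon bound to the amine nitrogen gives no change at the digits printed from compound 2 to compound 4 (within the scatter) too, the first one-place step read away from the phenoxy ring.

Nothing available gives a reason for these flat steps. From the compounds shown here alone, whether a carboxylic acid or an amine on the phenoxy ring would shift the value remains open.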